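Swapping amino for methyl on the shared core

This account rests on a few compounds, and the source may have more. Where it says the series, first, only, none or still open, it means among the compounds named here.

Measured so far in a functional assay on MCF7 cells (Homo sapiens) for inhibition, with a stated time of 48 h; on this read-out higher numbers stand for weaker inhibition and lower numbers for stronger inhibition:
- compound 1 `COc1cc(Sc2c[nH]c3ccc(F)cc23)cc(OC)c1OC`: 160 nM
- compound 2 `COc1cc(Sc2c[nH]c3ccc(N)cc23)cc(OC)c1OC`: 260 nM

In this assay, within the data shown here, compound 2 gives 260 nM, and that number lies within the usual scatter of the one for compound 1, which gives 160 nM. The two can therefore not be told apart on these data.

The next compound is compound 3 `COc1cc(Sc2c[nH]c3ccc(C)cc23)cc(OC)c1OC`, which carries methyl in place of amino on an aromatic carbon. Among the measured compounds shown here, only one measured step bears on this change. It altered the group at the same place on the core, and it is a 1.6-fold higher number from compound 1 to compound 2 (0.21 log units; within the scatter). For the measured compounds named here, no measured compound carries methyl, so the data offer no direct reading for this group, and a single step is thin evidence.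

Because a 1.6-fold higher number from compound 1 to compound 2 (0.21 log units; within the scatter) stayed so small, no step beyond the scatter is expected in this assay. The expected step is a 1.4-fold lower number from compound 2 to compound 3 (0.16 log units; within the scatter). Compound 3 is estimated to give 180 nM, with an expected range from 60 nM to 500 nM.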

Compound 3, half-maximal inhibitory concentration: 16 nM
Beside the measured number, compound 3's estimate is 11-fold (1.05 log units) above it; the measured number lies below the stated range.
By their numbers in this assay, from the lowest: compound 3; then compounds 1 and 2 (each within the scatter of the next).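

In this assay, this position proves far from indifferent to what it carries, even though amino and fluoro could not be told apart. Methyl in place of amino gives a 16-fold lower number from compound 2 to compound 3 (1.21 log units; beyond the scatter), and methyl in place of fluoro gives a 10-fold lower number from compound 1 to compound 3 (1.00 log units; beyond the scatter), so compound 3 stands clearly apart from both of the others. Amino and methyl each count 1 heavy atom, so a large step here needs no change in that count, and nothing measured here gives a reason for the step.

As far as these compounds go, what remains open is whether this low number is particular to methyl or extends to other small groups on the same aromatic carbon, such as ethyl, a longer chain, chloro, methoxy or trifluoromethyl, which would show how far the gain reaches. From the compounds shown here alone, it is equally open whether methyl would give a similar step in other cell lines, since all three numbers come from one cell line at one stated time.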